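A few compounds are considered here, and "the series" means these few. Any claim that something is new, unique, unknown or untested is made for them only; others in the source may bear on it.

Measured in a functional assay on HCT-15 cells (Homo sapiens) for inhibition; a higher number here means a weaker inhibitor of growth, a lower number a stronger inhibitor of growth:
- compound 1 `COc1cc(/C=C/c2ccc(S(N)(=O)=O)cc2)cc(OC)c1`: 17400 nM
- compound 2 `NS(=O)(=O)c1ccc(/C=C/c2ccc(F)cc2)cc1`: 9980 nM
- compound 3 `NS(=O)(=O)c1ccc(/C=C/c2cccc(O)c2)cc1`: 22800 nM

Compound 2 at 9980 nM lies within the scatter of compound 1 at 17400 nM. Compound 3 at 22800 nM stands beyond the scatter from compound 2, with the higher number.

Compound 4 `CN(C)c1ccc(/C=C/c2ccc(S(N)(=O)=O)cc2)cc1` carries dimethylamino in place of fluoro on an aromatic carbon, para to a large group (dimethylamino in place of fluoro on an aromatic carbon). For the measured compounds named here, no measured pair isolates a single change, so the guide is only the spread of the three values. No step beyond the scatter is expected in this assay. The expected step is a 1.2-fold higher number from compound 2 to compound 4 (0.08 log units; within the scatter). Compound 4 is estimated at 12000 nM, with an expected range of 4000 nM to 35000 nM.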

Compound 4, concentration for 50% growth inhibition: 17100 nM
Compound 4: the middle estimate sits 1.4-fold (0.15 log units) below what was measured, within the range that was stated.
By their numbers in this assay, from the lowest: compounds 2, 4, 1 and 3 (each within the scatter of the next, the first and the last beyond it).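

this assay now has its first comparison of compounds differing in one place: a 1.7-fold higher number from compound 2 to compound 4 (0.23 log units; within the scatter) for dimethylamino in place of fluoro on an aromatic carbon, para to a large group. At this position, the exchange therefore gives no step beyond the scatter, despite the change from fluoro to dimethylamino. No available evidence bears on this result.

Going by these compounds, whether an amine, a carboxylic acid or a longer chain at this position would give a step beyond the scatter remains open. For the compounds shown here, the single pair also cannot show whether the same exchange would behave alike elsewhere on the shared core.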